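The source may hold more compounds than are shown below. What is called first, only, known or untested is meant among the compounds shown, and "the series" means these compounds.

Measured so far, each in an assay on isolated protein for inhibition of Amine oxidase [flavin-containing] B (Homo sapiens), read by fluorescence and Amplex Red, with stated times of 15 min and 20 min; a higher number here means a weaker inhibitor, a lower number a stronger inhibitor:

Compound 1, `O=C(NC1CCN(Cc2ccccc2)CC1)c1coc2ccccc2c1=O`, gives 17700 nM.
Compound 2, `COc1ccc2c(=O)c(C(=O)NC3CCN(Cc4ccccc4)CC3)coc2c1`, gives 28600 nM.
Compound 3, `O=C(NCCC1CCN(Cc2ccccc2)CC1)c1coc2ccccc2c1=O`, gives 35300 nM.

Compound 4, `COc1ccc2occ(C(=O)NCCC3CCN(Cc4ccccc4)CC3)c(=O)c2c1`, has not yet been measured in this assay. It differs from compound 3 by methoxy in place of hydrogen on an aromatic carbon. The same change separates compound 1 from compound 2, namely (methoxy in place of hydrogen on an aromatic carbon), and there it made a 1.6-fold higher number from compound 1 to compound 2 (0.21 log units; within the scatter). The two places described are the same word for word, so this is the same change made on a second core. How the core of compound 3 differs from the core of compound 1 is not broken down here; the values of compound 3 and compound 1 stand within the usual scatter of each other, as do those of compound 3 and compound 2.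

For the measured compounds named here, with only one earlier example of the change, and that one within the scatter, compound 4 is expected to sit close to compound 3, and the step expected is a 1.4-fold higher number from compound 3 to compound 4 (0.15 log units; within the scatter), resting on the earlier step of a 1.6-fold higher number from compound 1 to compound 2 (0.21 log units; within the scatter). Compound 4 is therefore estimated at 50000 nM, with a plausible range from 22000 nM to 120000 nM.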

Compound 4, half-maximal inhibitory concentration: 11200 nM
Estimate against measurement, compound 4: 4.5-fold (0.65 log units) above; measured number below the stated range.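

In this assay, putting methoxy in place of hydrogen on an aromatic carbon gave a 3.2-fold lower number from compound 3 to compound 4 (0.50 log units; beyond the scatter), and a lower number here means a stronger inhibitor. Set beside the earlier case, the change did not carry over from one core to the other, since the two steps point in opposite directions and the gap between them is larger than scatter alone would explain: the same change on two cores in this assay, a 1.6-fold higher number (0.21 log units; within the scatter) from compound 1 to compound 2 and a 3.2-fold lower number (0.50 log units; beyond the scatter) from compound 3 to compound 4, 5.1-fold (0.71 log units) apart, beyond the scatter of two such steps. For the compounds shown here, this shows that a result for methoxy on one core cannot simply be transferred to the other, but with only two pairs it does not show which difference between the cores matters, or what the change would do on any further core.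

The compounds shown leave open whether a hydroxyl or a chlorine in the place of the methoxy would follow the same course on the two cores. Going by these compounds alone, they also leave open how a chain longer than the one in compound 3 would respond to the methoxy.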